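Compound 3 at the limit: a ring contraction

This account rests on a few compounds, and the source may have more. Where it says the series, first, only, none or still open, it means among the compounds named here.

In a functional assay on SK-BR-3 cells (Homo sapiens) for antiproliferative activity (on this read-out lower numbers stand for stronger inhibition and higher numbers for weaker inhibition), compound 1 `CC(C)=CCc1cc(C(=O)Nc2cc3ccc(OCC4CCCN(C)C4)c(C)c3oc2=O)ccc1O` gives 1300 nM and compound 2 `CC(C)=CCc1cc(C(=O)Nc2cc3ccc(OCC4CCN(C)C4)c(C)c3oc2=O)ccc1O` gives 920 nM. Compound 3 `CC(C)=CCc1cc(C(=O)Nc2cc3ccc(OCCCN4CCCCC4)c(C)c3oc2=O)ccc1O` has only a limit, > 50000 nM. The large steps of an at least 38-fold higher number from compound 1 to compound 3 (1.58 log units; beyond the scatter) and an at least 54-fold higher number from compound 2 to compound 3 (1.73 log units; beyond the scatter) set compound 3 well apart from the other two. Compound 4 `CC(C)=CCc1cc(C(=O)Nc2cc3ccc(OCCCN4CCCC4)c(C)c3oc2=O)ccc1O` carries pyrrolidin-1-yl in place of piperidin-1-yl on a saturated chain carbon, three bonds along the chain from an oxygen on an aromatic ring. The closest measured parallel, a six-membered ring exchanged for a five-membered one, is a 1.4-fold lower number from compound 1 to compound 2 (0.15 log units; within the scatter), which stays within the scatter. On that parallel, no step beyond the scatter is expected in this assay, and the expected step is an at least 1.2-fold lower number from compound 3 to compound 4 (0.09 log units; that floor lies within the scatter). The estimate for compound 4 is 40000 nM, with an expected range of 5000 nM to 60000 nM.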

Compound 4, half-maximal inhibitory concentration: 720 nM
Compound 4: the middle estimate sits 56-fold (1.74 log units) above what was measured; the measured number lies below the stated range.
By their numbers in this assay, from the lowest: compounds 4, 2 and 1 (each within the scatter of the next). At a limit, above all of these: compound 3.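

In this assay, the change from 3-(piperidin-1-yl)propyl to 3-(pyrrolidin-1-yl)propyl is far from neutral (an at least 69-fold lower number from compound 3 to compound 4 (1.84 log units; beyond the scatter)), whereas the ring exchange from compound 1 to compound 2 stayed within the scatter. Compound 4 sits level with the two compounds bearing a ring-bound nitrogen (a 1.3-fold lower number from compound 2 to compound 4 (0.11 log units; within the scatter); a 1.8-fold lower number from compound 1 to compound 4 (0.26 log units; within the scatter)), so among these four only compound 3 stands apart. Compound 3 has only a limit, so its step to compound 4 is a floor: the limit of > 50000 nM in this assay, at which 1 of the 4 values shown sits.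

What sets compound 3 apart remains unresolved. A morpholine or a dimethylamine on the same chain, or pyrrolidin-1-yl on a longer chain, would show whether the loss is peculiar to piperidin-1-yl.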